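The compounds below may be only part of what the source reports. "The series", "measured", "known", "first", "only" and "open" are said of these compounds alone.

Compound 3 `COc1ccc(COc2ccccc2OCCNCCOc2c(OC)cccc2OC)cc1` is the second highest of three numbers in a functional assay on PC-3 cells (Homo sapiens) for cytotoxicity, read by sulforhodamine B assay (on this read-out lower numbers stand for stronger inhibition of growth and higher numbers for weaker inhibition of growth), where compound 3 gives 34700 nM. Compound 1 `COc1cccc(OC)c1OCCNCCOc1ccccc1OCc1ccccc1` gives 76900 nM and compound 2 `COc1cccc(COc2ccccc2OCCNCCOc2c(OC)cccc2OC)c1` gives 15100 nM. The steps among them are a 2.2-fold lower number from compound 1 to compound 3 (0.35 log units; beyond the scatter), a 5.1-fold lower number from compound 1 to compound 2 (0.71 log units; beyond the scatter) and a 2.3-fold higher number from compound 2 to compound 3 (0.36 log units; beyond the scatter). Compound 4 `CCOc1ccc(COc2ccccc2OCCNCCOc2c(OC)cccc2OC)cc1` differs from compound 3 by methyl in place of hydrogen on a saturated chain carbon bound to an oxygen on an aromatic ring. Among the measured compounds shown here, none of the measured steps tests this change; they add or move a methoxy group rather than grow it, so the measured data give no direct guide. The step of a 1.2-fold lower number from compound 3 to compound 4 (0.06 log units; within the scatter) is therefore expected to stay within the scatter, with the number for compound 4 estimated at 30000 nM, likely between 12000 nM and 80000 nM.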

Compound 4, concentration for total growth inhibition: 18200 nM
Beside the measured number, compound 4's estimate is 1.6-fold (0.22 log units) above it, within the range that was stated.
By their numbers in this assay, from the lowest: compounds 2, 4 and 3 (each within the scatter of the next, the first and the last beyond it); then compound 1.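

Lengthening 4-methoxyphenyl to 4-ethoxyphenyl gives (a 1.9-fold lower number from compound 3 to compound 4 (0.28 log units; within the scatter)), so in this assay this first test of growing the group at this position shows no real shift. Compound 4 also stays level with the 3-methoxyphenyl compound (a 1.2-fold higher number from compound 2 to compound 4 (0.08 log units; within the scatter)), and it shows a clear gain over the unsubstituted compound (a 4.2-fold lower number from compound 1 to compound 4 (0.63 log units; beyond the scatter)). Nothing measured here explains these numbers. From the compounds shown here alone, whether a longer chain such as propoxy, or an amine in place of the ethoxy, would keep this level of growth inhibition remains open.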